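This account rests on a few compounds, and the source may have more. Where it says the series, first, only, none or still open, it means among the compounds named here.

Working notes on the series. Within the data shown here, in a functional assay on CCRF-CEM cells (Homo sapiens) for cytotoxicity, in the absence of a further agent (a higher number here means a weaker inhibitor, a lower number a stronger inhibitor), compound 1 `Nc1nc(N)c(CCCNc2cc(F)c(F)cc2[N+](=O)[O-])c(O)n1` gives 97000 nM, the highest of the two numbers so far; its nearest neighbour, compound 2 `Nc1nc(N)c(CCCN(Cc2ccc(NC(CCC(=O)O)C(=O)O)cc2)c2cc(F)c([N+](=O)[O-])cc2[N+](=O)[O-])c(O)n1`, gives 40000 nM in this assay, a gap beyond the usual scatter. Compound 3 `COC(=O)c1ccc(CN(CCCc2c(N)nc(N)nc2O)c2cc(F)c(F)cc2[N+](=O)[O-])cc1` is not yet measured. Against compound 1 it shows (4-(methoxycarbonyl)benzyl in place of hydrogen on a nitrogen on an aromatic ring). Among the measured compounds shown here, no measured step of this kind is on hand; the only comparison available is the pair of compound 1 and compound 2, which share no single-point difference with this step. Compound 3 is expected to sit somewhat lower than compound 1, by an estimated 2.4-fold lower number from compound 1 to compound 3 (0.38 log units; beyond the scatter), though a step within the scatter is also possible. The estimate for compound 3 in this assay is 40000 nM, with a range from 12000 nM to 130000 nM.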

Compound 3, half-maximal inhibitory concentration: 59000 nM
Beside the measured number, compound 3's estimate is 1.5-fold (0.17 log units) below it; the range from low to high includes it.
By their numbers in this assay, from the lowest: compounds 2, 3 and 1 (each within the scatter of the next, the first and the last beyond it).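

In this assay, among these compounds, the first single-point step, 4-(methoxycarbonyl)benzyl in place of hydrogen on a nitrogen on an aromatic ring gives a 1.6-fold lower number from compound 1 to compound 3 (0.22 log units; within the scatter). This nitrogen therefore carries a group of 11 heavy atoms, with its six-membered aromatic ring, without a step beyond the scatter. Nothing on hand explains this result.

Going by these compounds, whether a plain benzyl or a methyl group on this nitrogen would stay within the scatter remains open. So does the outcome of a carboxylic acid in place of the methyl ester.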